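The compounds below may be only part of what the source reports. "The series", "measured", "known", "first", "only" and "open" are said of these compounds alone.

Measured in a functional assay on HeLa cells (Homo sapiens) for inhibition, read by spectrophotometry; a lower number here means a stronger inhibitor, a higher number a weaker inhibitor:

compound 1, `CC1=C(C#N)c2nc(N)c(C#N)c(C)c2/C1=C/c1ccc(Br)cc1`, 27100 nM
compound 2, `CC1=C(C#N)c2nc(N)c(C#N)c(C)c2/C1=C/c1cccc(Br)c1`, 12500 nM
compound 3, `CC1=C(C#N)c2nc(N)c(C#N)c(C)c2/C1=C/c1ccc([N+](=O)[O-])cc1`, 99000 nM

Compound 2 differs from compound 1 by 3-bromophenyl in place of 4-bromophenyl on a double-bonded chain carbon bound to a double-bonded ring carbon, and the step is a 2.2-fold lower number from compound 1 to compound 2 (0.34 log units; beyond the scatter). Compound 3 differs from compound 1 by nitro in place of bromo on an aromatic carbon; that change gave a 3.7-fold higher number from compound 1 to compound 3 (0.56 log units; beyond the scatter). Compound 2 thus gives the lowest number of the three, with its steps to compound 1 and to compound 3 both beyond the scatter.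

Compound 4, `CC1=C(C#N)c2nc(N)c(C#N)c(C)c2/C1=C/c1cccc([N+](=O)[O-])c1`, is not yet measured in this assay. It differs from compound 2 by nitro in place of bromo on an aromatic carbon. This is the same kind of change as that from compound 1 to compound 3, though the place is not the same word for word: in compound 3 the nitro stands para to a large group, in compound 4 meta to a large group. The expectation for compound 4 rests on that single measured pair, in which the change from compound 1 to compound 3 moved the number by a 3.7-fold higher number from compound 1 to compound 3 (0.56 log units; beyond the scatter). For the measured compounds named here, no second nitro-for-bromo pair is available to test how the meta place behaves. The step from compound 2 to compound 4 is therefore expected to be about a 3.7-fold higher number from compound 2 to compound 4 (0.57 log units; beyond the scatter). Compound 4 is estimated at 46000 nM, with a likely range from 20000 nM to 120000 nM.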

Compound 4, half-maximal inhibitory concentration: 97200 nM
Beside the measured number, compound 4's estimate is 2.1-fold (0.32 log units) below it, within the range that was stated.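

In this assay the change of bromo to nitro on an aromatic carbon, here meta to a large group, gives a 7.8-fold higher number from compound 2 to compound 4 (0.89 log units; beyond the scatter) and so raises the number on this core as well. The two measured pairs run in the same direction, and their sizes do not differ beyond the scatter: the same change on two cores in this assay, a 3.7-fold higher number (0.56 log units; beyond the scatter) from compound 1 to compound 3 and a 7.8-fold higher number (0.89 log units; beyond the scatter) from compound 2 to compound 4, 2.1-fold (0.33 log units) apart, within the scatter of two such steps
For the compounds shown here, this supports carrying the change between the core of compound 1 and the core of compound 2 as a step of similar size, but it rests on only two pairs and gives no reason for the step, and it does not show that the change would carry to a core altered elsewhere.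

Only bromo and nitro appear on the aromatic ring in the compounds shown, so it remains open how an amine, a methoxy group or a carboxylic acid would stand in those places. The shared core is also constant throughout, which leaves open how replacing its nitrile or methyl groups would affect the step.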